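This account rests on a few compounds, and the source may have more. Where it says the series, first, only, none or still open, it means among the compounds named here.

Working notes on the series.

In an ADME assay on Caco-2 cells (Homo sapiens) for permeability, read by LC-MS, in the apical to basolateral direction, with a stated time of 60 min, at pH 6.5 (a higher number here means that the compound crosses the layer faster, a lower number that the compound crosses the layer more slowly), compound 1 `O=C(NCc1cc(Cl)ccc1-n1cnnn1)[C@@H]1C[C@@H]2C[C@@H]2N1C(=O)[C@H](O)Cn1cccn1` gives 0.45 10^-6 cm/s. Compound 2 `CC(C)(C)OC[C@@H](O)C(=O)N1[C@H](C(=O)NCc2cc(Cl)ccc2-n2cnnn2)C[C@@H]2C[C@@H]21` carries the change (tert-butoxy in place of 1H-pyrazol-1-yl on a saturated chain carbon, two bonds along the chain from a carbonyl carbon and an oxygen on a saturated carbon), and in this assay compound 2 gives 4.5 10^-6 cm/s, so that the step is a 10-fold higher number from compound 1 to compound 2 (1.00 log units; beyond the scatter).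

Compound 3 `O=C(NCc1cc(Cl)ccc1-n1cnnn1)[C@@H]1[C@H]2C[C@H]2CN1C(=O)[C@H](O)Cn1cccn1` has the same atoms as compound 1, joined differently; the difference between the two cores is not broken down here. In this assay compound 3 gives 0.31 10^-6 cm/s, which stands within the scatter of the number for compound 1, so no order between the two can be claimed.

Compound 4 `CC(C)(C)OC[C@@H](O)C(=O)N1C[C@@H]2C[C@@H]2[C@H]1C(=O)NCc1cc(Cl)ccc1-n1cnnn1` has not yet been measured in this assay. It differs from compound 3 by tert-butoxy in place of 1H-pyrazol-1-yl on a saturated chain carbon, two bonds along the chain from a carbonyl carbon and an oxygen on a saturated carbon, the same change that separates compound 1 from compound 2, at the same place described in the same words. The expected step is a 10-fold higher number from compound 3 to compound 4 (1.00 log units; beyond the scatter), and this expectation rests on the measured step of a 10-fold higher number from compound 1 to compound 2 (1.00 log units; beyond the scatter), carried over to the core of compound 3. Compound 4 is accordingly estimated at 3.1 10^-6 cm/s, with the measured number expected to fall between 1.2 10^-6 cm/s and 8 10^-6 cm/s. The measurement will show whether the second core carries the change in the same way.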

Compound 4, apparent permeability: 17 10^-6 cm/s
Compound 4: the middle estimate sits 5.5-fold (0.74 log units) below what was measured; measured number above the stated range.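

In this assay, tert-butoxy in place of 1H-pyrazol-1-yl gives a 55-fold higher number from compound 3 to compound 4 (1.74 log units; beyond the scatter) and the direction of the step on the core of compound 1 therefore holds on the core of compound 3. The size of the step does not carry over from one core to the other: the same change on two cores in this assay, a 10-fold higher number (1.00 log units; beyond the scatter) from compound 1 to compound 2 and a 55-fold higher number (1.74 log units; beyond the scatter) from compound 3 to compound 4, 5.5-fold (0.74 log units) apart, beyond the scatter of two such steps. This rests on a single change and a single pair of cores, so it shows neither why the step is larger on the core of compound 3 nor how any other group would behave on these two cores.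

The compounds shown vary this chain only from (1H-pyrazol-1-yl)methyl to (tert-butoxy)methyl, so it remains open whether the two cores also part for other groups. A chain ending in an amine or a carboxylic acid, or a longer ether chain, on both cores would test this, and the compounds shown say nothing beyond this assay.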